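A few compounds are considered here, and "the series" means these few. Any claim that something is new, unique, unknown or untested is made for them only; others in the source may bear on it.

The three compounds share one core and differ only in the ring attached to the carbonyl carbon of the amide. Compound 1 `O=C(Nc1cccc(-c2oc3cc(-c4ccc(F)cc4)ccc3c(=O)c2O)c1)c1ccccc1F` carries a 2-fluorophenyl there, and in a functional assay on HepG2 cells (Homo sapiens) for antiproliferative activity, read by CCK-8 assay, with a stated time of 72 h (a lower number here means a stronger inhibitor, a higher number a weaker inhibitor), compound 1 gives 10100 nM. Compound 2 `Cc1ccc(C(=O)Nc2cccc(-c3oc4cc(-c5ccc(F)cc5)ccc4c(=O)c3O)c2)cc1` carries a 4-methylphenyl, and in this assay compound 2 gives 2320 nM. Compound 3 `COc1ccccc1C(=O)Nc1cccc(-c2oc3cc(-c4ccc(F)cc4)ccc3c(=O)c2O)c1` carries a 2-methoxyphenyl, and in this assay compound 3 gives 14500 nM. Among these three numbers compound 1 stands second highest: its step to compound 3 is a 1.4-fold higher number from compound 1 to compound 3 (0.16 log units; within the scatter), while its step to compound 2 is a 4.4-fold lower number from compound 1 to compound 2 (0.64 log units; beyond the scatter).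

Compound 4 `O=C(Nc1cccc(-c2oc3cc(-c4ccc(F)cc4)ccc3c(=O)c2O)c1)c1cccc(F)c1` has not yet been measured. Its difference from compound 1 is 3-fluorophenyl in place of 2-fluorophenyl on a carbonyl carbon. Going by the values given here, no measured step moves a fluorine around this ring, so the known steps bear on it only indirectly: a 1.4-fold higher number from compound 1 to compound 3 (0.16 log units; within the scatter) shows that swapping the fluoro for methoxy changes little, whereas a 4.4-fold lower number from compound 1 to compound 2 (0.64 log units; beyond the scatter) and a 6.3-fold higher number from compound 2 to compound 3 (0.80 log units; beyond the scatter) show that the 4-methylphenyl gives a clearly lower number than either. The step of a 1.6-fold lower number from compound 1 to compound 4 (0.19 log units; within the scatter) is therefore expected to be small, within the scatter, perhaps leaning downward. Compound 4 is estimated at 6500 nM, in a range from 2500 nM to 16000 nM.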

Compound 4, half-maximal inhibitory concentration: 15500 nM
Beside the measured number, compound 4's estimate is 2.4-fold (0.38 log units) below it; low and high end bracket the measured number.
By their numbers in this assay, from the lowest: compound 2; then compounds 1, 3 and 4 (each within the scatter of the next).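

Moving the fluorine on the ring attached to the carbonyl carbon gives a 1.5-fold higher number from compound 1 to compound 4 (0.19 log units; within the scatter) in this assay, so the 2-fluorophenyl and 3-fluorophenyl groups cannot be told apart here. The 3-fluorophenyl group also cannot be separated from the 2-methoxyphenyl group, with a 1.1-fold higher number from compound 3 to compound 4 (0.03 log units; within the scatter), whereas a 6.7-fold higher number from compound 2 to compound 4 (0.82 log units; beyond the scatter) leaves the 4-methylphenyl group of compound 2 as the only one of these four that stands clearly apart. Nothing available explains why these groups give these numbers.

On these data alone, whether the lower number of compound 2 goes with the methyl group itself or with the place it holds on the ring remains open. A 4-fluorophenyl or a 2-methylphenyl group on the same carbonyl carbon would help separate those two readings, and a ring carrying an amine or a carboxylic acid would extend the comparison to other kinds of group.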